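Series notes: sulfanyl chain variation and adenosine receptor inhibition

The source may report more compounds than this note shows. Statements on the series, on what has been measured and on what is new or still open speak of the compounds shown alone.

Three members of the series carry the same core and differ only in the group on the saturated chain carbon bound to a sulfur. Compound 1 `N#Cc1c(N)nc(SCC(N)=O)c(C#N)c1-c1ccc(OCC2CC2)cc1` gives 31% in an assay on CHO cells for displacement of a labelled ligand from adenosine receptor A1 (Homo sapiens), read by scintillation counting, with a stated time of 90 min, tested at 1 uM; on this read-out lower numbers stand for less inhibition and higher numbers for more inhibition at the one concentration tested (going by the name of the read-out); compound 2 `CNC(=O)CSc1nc(N)c(C#N)c(-c2ccc(OCC3CC3)cc2)c1C#N` gives 14% in this assay; compound 3 `N#Cc1c(N)nc(SCc2cnc[nH]2)c(C#N)c1-c1ccc(OCC2CC2)cc1` gives 1% in this assay. Compound 3 stands lowest of the three, with a number 13 percentage points lower from compound 2 to compound 3 (beyond the scatter) and a number 30 percentage points lower from compound 1 to compound 3 (beyond the scatter); between the two carbamoyl-type members the step is a number 17 percentage points lower from compound 1 to compound 2 (beyond the scatter).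

Compound 4 `COC(=O)CSc1nc(N)c(C#N)c(-c2ccc(OCC3CC3)cc2)c1C#N` has not yet been measured in this assay. It differs from compound 3 by methoxycarbonyl in place of 1H-imidazol-5-yl on a saturated chain carbon bound to a sulfur. The two steps that bear on this are the reverse of the steps into compound 3: both carbamoyl and methylcarbamoyl gave more inhibition than 1H-imidazol-5-yl at this position, by a modest amount. Methoxycarbonyl is neither of these, so the expected step is taken as a modest rise, a number 19 percentage points higher from compound 3 to compound 4 (beyond the scatter), placing compound 4 between compound 2 and compound 1. Compound 4 is therefore estimated at 20%, within a range of 5% to 38%.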

Compound 4, a percentage reported as inhibition, at one concentration (the size of the read-out at that concentration, not a potency): 23%
Compound 4: middle estimate off by 3 percentage points, on the low side; the measured number falls inside the stated range.
By their numbers in this assay, from the lowest: compound 3; then compounds 2, 4 and 1 (each within the scatter of the next, the first and the last beyond it).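

The change to methoxycarbonyl on a saturated chain carbon bound to a sulfur gives a number 22 percentage points higher from compound 3 to compound 4 (beyond the scatter) in this assay, so 1H-imidazol-5-yl now stands apart from three carbonyl-bearing groups rather than two. On the carbonyl carbon, methoxy in place of methylamino gives a number 9 percentage points higher from compound 2 to compound 4 (within the scatter) and methoxy in place of amino gives a number 8 percentage points lower from compound 1 to compound 4 (within the scatter), although the two amide members are separated by more than the scatter. An amide-type nitrogen is therefore not needed for a reading in this range, since methoxycarbonyl, with 0 hydrogen-bond donors, cannot be told apart from either carbamoyl or methylcarbamoyl.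

The compounds shown leave open how a carboxylic acid or a dimethylcarbamoyl group on this carbon would read, and whether a longer chain carrying methoxycarbonyl would hold the same level. No information is available on why these groups differ.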